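The compounds below may be only part of what the source reports. "The series", "measured", "known", "first", "only" and "open" are said of these compounds alone.

Measured compounds in a functional assay on HCT-15 cells (Homo sapiens) for inhibition, read by sulforhodamine B assay, with a stated time of 48 h; a higher number here means that more compound is tolerated, a lower number that less compound is tolerated:

Compound 1 `Nc1cc(N)c2nc(-c3ccccc3)c(Oc3ccc(Cl)c(Cl)c3)nc2c1`. In this assay compound 1 gives < 100000 nM, which is a limit of the assay rather than a number.
Compound 2 `CCOC(=O)[C@H](CCC(=O)O)NC(=O)c1ccc(Sc2nc3cc(N)cc(N)c3nc2-c2ccccc2)cc1`. Compound 2 gives < 100000 nM, again a limit.
Compound 3 `CCOC(=O)[C@H](CCC(=O)O)NC(=O)c1ccc(Oc2nc3cc(N)cc(N)c3nc2-c2ccccc2)cc1`. Compound 3 gives < 100000 nM, also a limit.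

Compound 1 therefore stands only at a limit in this assay, and the two other measured compounds stand at the same limit, as the limit of < 100000 nM in this assay, at which 3 of the 3 values shown sit, records. For the measured compounds named here, no pair of measured compounds differs in one place, so no measured step is available for sizing the change that follows.

Compound 4 `Nc1cc(N)c2nc(-c3ccccc3)c(Sc3ccc(F)cc3)nc2c1` differs from compound 1 by (4-fluorophenyl)sulfanyl in place of 3,4-dichlorophenoxy on an aromatic carbon. Going by the values given here, with every recorded value a limit and no measured step in hand, the expected size of the step from compound 1 to compound 4 cannot be anchored; the expectation is for no step beyond the usual scatter, written as a step that the limit leaves unreadable from compound 1 to compound 4. Compound 4 is estimated at 50000 nM, with a range from 10000 nM to 100000 nM, and with a substantial chance that this assay again reports only a limit for compound 4.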

Compound 4, concentration lethal to 50% of the cells: 56200 nM
The estimate for compound 4 lay 1.1-fold (0.05 log units) below the measured number; measured number inside the range.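

No step can be read between compound 1 and compound 4, as compound 1 stands only at a limit: the limit of < 100000 nM in this assay, at which 3 of the 4 values shown sit.

The compounds shown leave open whether (4-fluorophenyl)sulfanyl in place of 3,4-dichlorophenoxy on an aromatic carbon changes the tolerated concentration at all, and by how much.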